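This account rests on a few compounds, and the source may have more. Where it says the series, first, only, none or still open, it means among the compounds named here.

Measured so far in an assay on HEK293 cells for inhibition of sodium-dependent dopamine transporter (Homo sapiens); a lower number here means a stronger inhibitor, a higher number a weaker inhibitor:
compound 1 `CNCc1cc(NS(C)(=O)=O)ccc1Sc1ccc(SC)cc1` gives 3800 nM
compound 2 `CN(C)Cc1cc(C(N)=O)ccc1Oc1ccc(OC(F)(F)F)cc1` gives > 10000 nM

Compound 2 stands at the limit of this assay: its figure of > 10000 nM is a limit, not a number (the limit of > 10000 nM in this assay, at which 1 of the 2 values shown sits). Among the compounds with values here, compound 1 is the only compound with a measured figure, and it carries a methanesulfonamido group. Compound 3 `CN(C)Cc1cc(CNS(C)(=O)=O)ccc1Oc1ccc(OC(F)(F)F)cc1` is not yet measured; it carries (methanesulfonamido)methyl in place of carbamoyl on an aromatic carbon. Within the data shown here, no step between measured compounds covers this change. The step from compound 2 to compound 3 is expected to go toward stronger inhibition, beyond the scatter, as an at least 1.2-fold lower number from compound 2 to compound 3 (0.09 log units; that floor lies within the scatter). Compound 3 is expected near 8000 nM, within 2000 nM to 30000 nM.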

Compound 3, half-maximal inhibitory concentration: 5800 nM
Beside the measured number, compound 3's estimate is 1.4-fold (0.14 log units) above it, and the stated range covers the measured number.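

In this assay, (methanesulfonamido)methyl in place of carbamoyl, on the aromatic carbon para to a large group, gives an at least 1.7-fold lower number from compound 2 to compound 3 (0.23 log units; that floor lies within the scatter). For compound 2 the figure is a limit, not a number: the limit of > 10000 nM in this assay, at which 1 of the 3 values shown sits. On these data alone, this position therefore tolerates the larger group with a measurable read-out, but the true size of the step remains unknown.

As far as these compounds go, how an aminomethyl group, a carboxylic acid or a longer sulfonamide chain would read at this position remains open. Compound 1 differs from compound 3 in more than one place, so it cannot settle this.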